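A few compounds are considered here, and "the series" means these few. Any claim that something is new, unique, unknown or untested is made for them only; others in the source may bear on it.

Compound 1 `Nc1nnc(-c2ccccc2Sc2ccccc2)o1` and compound 3 `S=c1[nH]nc(-c2ccccc2Sc2ccccc2)[nH]1` share one core and differ only in that (a group of 6 heavy atoms (2 carbon, 3 nitrogen, 1 sulfur; one five-membered aromatic ring with 3 hetero atoms) in place of a group of 6 heavy atoms (2 carbon, 3 nitrogen, 1 oxygen; one five-membered aromatic ring with 3 hetero atoms), on an aromatic carbon). In a functional assay on the whole organism (strain NMRI) for inhibition, with Mus musculus as the target, in the formalin test, with a stated time of 30 min, at a dose of 30 umol/kg by the intraperitoneal route (on this read-out higher numbers stand for more inhibition at the one dose given (going by the name of the read-out) and lower numbers for less inhibition), compound 1 gives 16.6%, whereas compound 3 gives 49.4%, which amounts to a number 32.8 percentage points higher from compound 1 to compound 3 (beyond the scatter). Compound 2 `Nc1nnc(-c2ccccc2[S+]([O-])c2ccccc2)o1` is built on another core; the difference between the two cores is not broken down here. In this assay compound 2 gives 29.4%. Compound 4 `[O-][S+](c1ccccc1)c1ccccc1-c1n[nH]c(=S)[nH]1` has not yet been measured; it differs from compound 2 in that (a group of 6 heavy atoms (2 carbon, 3 nitrogen, 1 sulfur; one five-membered aromatic ring with 3 hetero atoms) in place of a group of 6 heavy atoms (2 carbon, 3 nitrogen, 1 oxygen; one five-membered aromatic ring with 3 hetero atoms), on an aromatic carbon). For the measured compounds named here, this is the same kind of change as the one between compound 1 and compound 3, though the surroundings of the place are not the same in compound 1 and compound 2, as the two counted differences show. Because the earlier step was a number 32.8 percentage points higher from compound 1 to compound 3 (beyond the scatter), for compound 4 a step of about a number 25.6 percentage points higher from compound 2 to compound 4 (beyond the scatter) is expected. Compound 4 is thus estimated at 55% in this assay.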

Compound 4, a percentage reported as inhibition, in the whole organism at one dose (the size of the read-out at that dose, not a potency): 31.7%
Compound 4: middle estimate off by 23.3 percentage points, on the high side; the whole stated range lies above it.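

In this assay, putting the sulfur-bearing ring in place of the 5-amino-1,3,4-oxadiazol-2-yl group gave a number 2.3 percentage points higher from compound 2 to compound 4 (within the scatter) on the core of compound 2. Set beside the earlier step, the same change did not carry over from one core to the other: the same change on two cores in this assay, a number 32.8 percentage points higher (beyond the scatter) from compound 1 to compound 3 and a number 2.3 percentage points higher (within the scatter) from compound 2 to compound 4, 30.5 percentage points apart, beyond the scatter of two such steps. This shows that a step measured on one core was a poor guide to the other in these two pairs, but it does not show which feature of the cores is responsible, and two pairs set no rule for the series.

Going by these compounds, it remains open how a carboxylic acid or a nitrile in this place would behave on either core. On these data alone, it is also open whether a further core would follow compound 3 or compound 4.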